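From a thiazolyl amide to a sulfonylphenyl amide

The source may report more compounds than this note shows. Statements on the series, on what has been measured and on what is new or still open speak of the compounds shown alone.

Compound 1 `Cc1nc(C(=O)Nc2ccc(Cl)c(-c3nnc4c(Cl)cccn34)c2)cs1` is an amide on a shared core. In a functional assay on AN3-CA cells (Homo sapiens) for antiproliferative activity, read by MTT assay, with a stated time of 72 h (a higher number here means a weaker inhibitor, a lower number a stronger inhibitor), compound 1 gives only a limit, > 100000 nM, so no number is known for it. Compound 2 `O=C(Nc1ccc(Cl)c(-c2nnc3c(Cl)cccn23)c1)c1ccc(Cl)cc1` carries 4-chlorophenyl in place of 2-methyl-1,3-thiazol-4-yl on the carbonyl carbon. In this assay compound 2 likewise gives only a limit, > 100000 nM. The step that the two limits leave unreadable from compound 1 to compound 2 therefore cannot be sized. Compound 3 `CS(=O)(=O)c1cccc(C(=O)Nc2ccc(Cl)c(-c3nnc4c(Cl)cccn34)c2)c1` varies the same place: 3-(methylsulfonyl)phenyl in place of 2-methyl-1,3-thiazol-4-yl on a carbonyl carbon. Within the data shown here, the only measured step that bears on it is the one from compound 1 to compound 2, and both of its ends sit at the limit of > 100000 nM in this assay, at which 2 of the 2 values shown sit, so neither a direction nor a size beyond the scatter can be read from it. For compound 3 a further limit is expected, with an estimated value of 100000 nM in a range from 30000 nM to 300000 nM. The step of a number no higher from compound 1 to compound 3 (the limit leaves the size open) is accordingly expected to be nil.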

Compound 3, half-maximal inhibitory concentration: > 100000 nM
Compound 3: no number, only a limit; the forecaster's own chance of this, stated with the estimate: 80%; the middle value lies on the limit itself.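

Compound 3 also gives only a limit, so no step among compound 1, compound 2 and compound 3 can be read in this assay: the limit of > 100000 nM in this assay, at which 3 of the 3 values shown sit.

The compounds shown leave open how the 2-methyl-1,3-thiazol-4-yl, 4-chlorophenyl and 3-(methylsulfonyl)phenyl groups rank, and whether any amide on the shared core gives a measurable number.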